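A Methoxy Group Added to the Benzyl Ring

The source may hold more compounds than are shown below. What is called first, only, known or untested is meant among the compounds shown, and "the series" means these compounds.

Compound 1 `O=S(=O)(NCCCNCC1COc2ccccc2O1)c1cc(C(F)(F)F)cc(C(F)(F)F)c1`: 1200 nM in a functional assay on BXPC-3 cells (Homo sapiens) for inhibition, read by MTT assay, with a stated time of 72 h; a lower number here means a stronger inhibitor of growth, a higher number a weaker inhibitor of growth
Compound 2 `O=S(=O)(NCCCNCc1ccccc1)c1cc(C(F)(F)F)cc(C(F)(F)F)c1`: 13000 nM in this assay

Among the measured compounds shown here, of the two measured compounds, compound 2 gives the higher number, and the only measured step, an 11-fold higher number from compound 1 to compound 2 (1.03 log units; beyond the scatter), separates it from compound 1. Compound 3 `COc1cccc(CNCCCNS(=O)(=O)c2cc(C(F)(F)F)cc(C(F)(F)F)c2)c1` differs from compound 2 by methoxy in place of hydrogen on an aromatic carbon. For the measured compounds named here, no measured step places a substituent on this ring: the step from compound 1 to compound 2 exchanges the whole group on the saturated chain carbon, so it bears on the present change only as a sign that this region of the molecule can shift the number strongly. Going by the values given here, with no direct precedent, a small step is expected: compound 3 is estimated at 8000 nM, between 3000 nM and 25000 nM, a change of a 1.6-fold lower number from compound 2 to compound 3 (0.21 log units; within the scatter) that may not exceed the scatter.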

Compound 3, concentration for 50% growth inhibition: 1700 nM
Compound 3: middle estimate off by 4.7-fold (0.67 log units), on the high side, outside the stated range (below it).
By their numbers in this assay, from the lowest: compounds 1 and 3 (each within the scatter of the next); then compound 2.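

On the benzyl ring, methoxy in place of hydrogen on an aromatic carbon, meta to a large group, is a single small change that moves the number in this assay beyond the scatter (a 7.6-fold lower number from compound 2 to compound 3 (0.88 log units; beyond the scatter)), showing that this ring, left unsubstituted in compound 2, responds to a substituent. With this one group in place, the 3-methoxybenzyl compound can no longer be told apart from the compound carrying 2,3-dihydro-1,4-benzodioxin-2-yl on the chain carbon (a 1.4-fold higher number from compound 1 to compound 3 (0.15 log units; within the scatter)), although the step to the plain phenyl had been large. No evidence bears on why the methoxy group has this effect.

Still open, on these data alone, is whether a hydroxy group, a chlorine atom or an ethoxy group at this place would act as methoxy does, and whether methoxy on another ring carbon would give the same step. Also open, as far as these compounds go, is whether the step would hold with a longer chain in the linker.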